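Swapping the Aromatic Group on a Hydrazone End

A few compounds are considered here, and "the series" means these few. Any claim that something is new, unique, unknown or untested is made for them only; others in the source may bear on it.

Compound 1 `CC1=CC[C@@H]([C@@](C)(O)CCCC(C)(C)NC(=S)NN)CC1` and compound 2 `CC1=CC[C@@H]([C@@](C)(O)CCCC(C)(C)NC(=S)N/N=C\c2ccc([N+](=O)[O-])cc2)CC1` share a core; compound 2 additionally carries a 4-nitrophenyl group on a carbon with a double bond to nitrogen. In a functional assay on K562 cells (Homo sapiens) for cytotoxicity, read by sulforhodamine B assay (on this read-out higher numbers stand for lower toxicity in this test and lower numbers for higher toxicity in this test), compound 1 gives 9580 nM. In this assay compound 2 gives 45500 nM, the higher of the two numbers, and its gap to compound 1 lies beyond the usual scatter, so compound 2 is the less toxic of the pair. Compound 3 `CC1=CC[C@@H]([C@@](C)(O)CCCC(C)(C)NC(=S)N/N=C\c2ccccc2Cl)CC1` keeps the shared core and differs from compound 2 in one place: 2-chlorophenyl in place of 4-nitrophenyl on a carbon with a double bond to nitrogen. Among the measured compounds shown here, no measured pair shows what exchanging one aromatic group for another does here, so the two values offer no guide to direction. The step is therefore expected to stay within the scatter or move only modestly; the expected step is a 1.5-fold lower number from compound 2 to compound 3 (0.18 log units; within the scatter). Compound 3 is estimated at 30000 nM, with a likely range from 10000 nM to 90000 nM.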

Compound 3, concentration lethal to 50% of the cells: 8500 nM
Estimate against measurement, compound 3: 3.5-fold (0.55 log units) above; the whole stated range lies above it.
By their numbers in this assay, from the lowest: compounds 3 and 1 (each within the scatter of the next); then compound 2.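

In this assay, the choice of aromatic group on this carbon clearly matters: 2-chlorophenyl in place of 4-nitrophenyl gives a 5.4-fold lower number from compound 2 to compound 3 (0.73 log units; beyond the scatter) and makes compound 3 the more toxic of that pair. Compound 3 and compound 1, which lacks the aromatic end altogether, stand level, with a 1.1-fold lower number from compound 1 to compound 3 (0.05 log units; within the scatter) as the listed step, so carrying an aromatic group at this end does not always go with a higher number. Nothing measured for these compounds explains why the two aromatic groups part ways.

Among the compounds shown here, with only two aromatic groups compared, and both the group and its substitution differing between them, it stays open whether the gap follows the nitro group or the chlorine. A plain phenyl, a 4-chlorophenyl or a 2-nitrophenyl on this carbon would help separate those two possibilities.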